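The source may hold more compounds than are shown below. What is called first, only, known or untested is meant among the compounds shown, and "the series" means these compounds.

Measured compounds:
- compound 1, `CC(C)(C(=O)O)c1nn(Cc2cn3cc(OCC4CC4)c(Cl)cc3n2)c2ccccc2c1=O`, 361 nM
- compound 2, `C[C@H](C(=O)O)n1nc(Cn2cc3cc(OCC4CC4)c(Cl)cc3n2)c2ccccc2c1=O`, 197 nM
- compound 3, `O=C(O)Cn1nc(Cc2cn3cc(OCC4CC4)c(Cl)cc3n2)c2ccccc2c1=O`, 275 nM

These three compounds share a common core and differ in the acid-bearing group and in how the side chain is joined to it. All were tested in a functional assay on HFL1 cells for antagonist activity at sphingosine 1-phosphate receptor 2 (Homo sapiens), read by ELISA, with a stated time of 24 h, in the presence of a further agent that is not named here; on this read-out lower numbers stand for stronger inhibition and higher numbers for weaker inhibition. On these numbers compound 1 carries the highest value, yet its gaps to compound 3 and to compound 2 both fall within the usual scatter of repeated measurement, so no ranking of the three can be claimed.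

Compound 4, `CC(C(=O)O)c1nn(Cc2cn3cc(OCC4CC4)c(Cl)cc3n2)c2ccccc2c1=O`, has not yet been measured. It differs from compound 1 in one place: hydrogen in place of methyl on a saturated chain carbon bound to an aromatic carbon, a carbonyl carbon and a saturated chain carbon. The change is small and trims the group to one that lies part-way between the groups of compound 1 and compound 3, whose values are within the scatter of each other.

For this assay, compound 4 is expected to give a number close to that of compound 1, with a step of a 1.2-fold lower number from compound 1 to compound 4 (0.10 log units; within the scatter) that stays within the scatter. The estimate for compound 4 is 290 nM, with a range from 120 nM to 700 nM.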

Compound 4, half-maximal inhibitory concentration: 15 nM
Compound 4: the middle estimate sits 19-fold (1.29 log units) above what was measured, outside the stated range (below it).
By their numbers in this assay, from the lowest: compound 4; then compounds 2, 3 and 1 (each within the scatter of the next).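

In this assay the change from 1-carboxy-1-methylethyl to 1-carboxyethyl, which removes a single methyl and no ring or charge, gives a 24-fold lower number from compound 1 to compound 4 (1.38 log units; beyond the scatter) and is a large step. This shows that the saturated chain carbon bound to an aromatic carbon, a carbonyl carbon and a saturated chain carbon is highly sensitive to what it carries, something the three earlier compounds could not reveal, as their numbers lay within the scatter of one another. Nothing measured here explains why the removal of this methyl has so large an effect.

Only this one exchange at this carbon is shown, so it remains open how an ethyl group or a hydroxyl group there would compare with the remaining methyl of compound 4. Compound 4 is also drawn without a defined spatial arrangement at this carbon, so which mirror-image form accounts for its number also remains open.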